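Methoxy for Methyl on the Pendant Aryl Ring

The source may report more compounds than this note shows. Statements on the series, on what has been measured and on what is new or still open speak of the compounds shown alone.

Compound 1 `O=c1oc2ccccc2c2nc3c(ccc4cc[nH]c43)c(-c3ccc(Br)cc3)c12`: in a functional assay on B16-F10 cells (Mus musculus) for cytotoxicity (on this read-out lower numbers stand for stronger inhibition and higher numbers for weaker inhibition), compound 1 gives 70700 nM.
Compound 2 `O=c1oc2ccccc2c2nc3c(ccc4cc[nH]c43)c(-c3ccccn3)c12`: in this assay compound 2 gives 70700 nM.
Compound 3 `Cc1ccc(-c2c3ccc4cc[nH]c4c3nc3c2c(=O)oc2ccccc23)cc1`: in this assay compound 3 gives 70700 nM.

Compound 3 stands level with compound 1 and compound 2 in this assay; all three sit at the same reading, and neither neighbour is separated from it beyond the scatter. Compound 4 `COc1ccc(-c2c3ccc4cc[nH]c4c3nc3c2c(=O)oc2ccccc23)cc1` carries the change (methoxy in place of methyl on an aromatic carbon).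

Among the measured compounds shown here, two measured steps touch the same aromatic carbon of the shared core. The step of no change at the digits printed from compound 1 to compound 3 (within the scatter) exchanges one substituent on that ring for another, and the step of no change at the digits printed from compound 1 to compound 2 (within the scatter) replaces the whole pendant ring; the step of no change at the digits printed from compound 2 to compound 3 (within the scatter) does likewise. Each of these moves leaves the reading in this assay where it was. A methoxy in place of a methyl on the same ring position is a change of comparable scale to those already tested, so no shift beyond the scatter is expected in this assay for compound 4, in either direction.

Compound 4 is therefore expected to give 70700 nM in this assay, within 35000 nM to 141000 nM, which corresponds to an expected step of no change at the digits printed from compound 3 to compound 4 (within the scatter).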

Compound 4, half-maximal inhibitory concentration: 70700 nM
Compound 4: middle estimate and measured number agree at the digits printed; the range from low to high includes it.
By their numbers in this assay, from the lowest: compounds 1, 2, 3 and 4 (each within the scatter of the next).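

In this assay, putting an oxygen, and with it a hydrogen-bond acceptor, on the aromatic carbon para to a large group gave no change at the digits printed from compound 3 to compound 4 (within the scatter) for methoxy in place of methyl, the first change shown that adds an oxygen to this pendant ring. Measured against the other two neighbours, the result is no change at the digits printed from compound 1 to compound 4 (within the scatter) on exchanging bromo for methoxy and no change at the digits printed from compound 2 to compound 4 (within the scatter) on exchanging pyridin-2-yl for 4-methoxyphenyl, so a fourth pendant ring now shares the same reading in this series. Nothing measured here accounts for the four readings coinciding.

All four compounds carry an aromatic ring at this place, which leaves open whether a ring bearing an amine or a carboxylic acid, or a longer chain such as butoxy in place of methoxy, would move the reading at all. Going by these compounds, what a change elsewhere on the shared core would do also stays open, as all four compounds keep it intact.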